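Ethyl to isopropyl on a core without measurable affinity

The source may hold more compounds than are shown below. What is called first, only, known or untested is meant among the compounds shown, and "the series" means these compounds.

compound 1, `CCn1cnc2ncnc(N)c21`: > 100000 nM
compound 2, `CC(C)n1cnc2c(N)ncnc21`: > 100000 nM

In an assay on CHO cells for displacement of a labelled ligand from adenosine receptor A3 (Homo sapiens) (on this read-out higher numbers stand for weaker inhibition and lower numbers for stronger inhibition), compound 1 gives > 100000 nM, which is a limit of the assay and not a number. Compound 2, with its alkyl group on the other ring nitrogen of the shared core, gives > 100000 nM in this assay, again a limit. Both values thus sit at the limit of > 100000 nM in this assay, at which 2 of the 2 values shown sit, so compound 1 stands at the floor of what this assay can report, with no measured number to place it against compound 2.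

Compound 3, `CC(C)n1cnc2ncnc(N)c21`, differs from compound 1 by methyl in place of hydrogen on a saturated chain carbon bound to an aromatic nitrogen and a saturated chain carbon. Within the data shown here, no step between measured compounds is available to guide the expectation. Since compound 1 gives > 100000 nM and compound 2 gives > 100000 nM, the change is expected to produce no step beyond the usual scatter, so that a number no higher from compound 1 to compound 3 (the limit leaves the size open) is expected to be essentially flat. Compound 3 is therefore expected to give 100000 nM in this assay, with a range from 30000 nM to 300000 nM, most likely reported only as a limit.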

Compound 3, inhibition constant: > 100000 nM
Compound 3 ended at the assay's limit (the forecaster's own chance of this, stated with the estimate: 85%); the middle value lies on the limit itself.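

No step can be read from compound 1 to compound 3, because their values are limits and not numbers: the limit of > 100000 nM in this assay, at which 3 of the 3 values shown sit.

The compounds shown leave open what number, if any, either alkyl group on the shared core would give in this assay, and so how large the change from ethyl to isopropyl is.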